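A few compounds are considered here, and "the series" means these few. Any claim that something is new, unique, unknown or untested is made for them only; others in the source may bear on it.

Compound 1 `CCOC(=O)N(C)C(C)C#CCn1ccnc1` is an ethyl carbamate whose chain ends in an imidazole. In a functional assay on the whole organism for antagonist activity, with Mus musculus as the target (a higher number here means that more compound is needed for the effect, a lower number that less compound is needed), compound 1 gives only a limit, > 100 mg/kg. Compound 2 `CCOC(=O)N(C)C(C)C#CCn1cncc1C` differs from it by methyl in place of hydrogen on an aromatic carbon, and in this assay compound 2 gives 30 mg/kg. That single change made the step of an at least 3.3-fold lower number from compound 1 to compound 2 (0.52 log units; beyond the scatter). Its size can be given only as a floor because compound 1 stands at the limit of > 100 mg/kg in this assay, at which 2 of the 3 values shown sit.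

Compound 3 `O=C1OCCN1CC#CCn1ccnc1` carries the same imidazole-tipped chain on a cyclic carbamate; the difference between its core and that of compound 1 is not broken down here. In this assay compound 3 gives only a limit, > 100 mg/kg.

Compound 4 `Cc1cncn1CC#CCN1CCOC1=O`, not yet measured, differs from compound 3 by methyl in place of hydrogen on an aromatic carbon, the same change that separates compound 1 from compound 2. It is therefore expected that compound 4 will show a step of an at least 2.0-fold lower number from compound 3 to compound 4 (0.30 log units; that floor lies within the scatter) from compound 3, an expectation resting on an at least 3.3-fold lower number from compound 1 to compound 2 (0.52 log units; beyond the scatter), though with a limit as starting point the outcome is uncertain. The value estimated for compound 4 in this assay is 50 mg/kg, somewhere between 15 mg/kg and 200 mg/kg.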

Compound 4, dose for half-maximal effect: > 100 mg/kg
Compound 4: no number, only a limit; the forecaster's own chance of this, stated with the estimate: 35%; at least 2.0-fold (0.30 log units) between middle value and limit.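

In this assay compound 4 gives only a limit, > 100 mg/kg, as compound 3 does, so no step from compound 3 to compound 4 can be read: the limit of > 100 mg/kg in this assay, at which 3 of the 4 values shown sit.

The compounds shown leave open whether methyl in place of hydrogen on an aromatic carbon changes the number at all on the core of compound 3, as it did on the core of compound 1.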